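Trading a chlorophenyl for ethyl on the ring amide carbonyl

This account rests on a few compounds, and the source may have more. Where it says the series, first, only, none or still open, it means among the compounds named here.

Compound 1, `CC(=O)N1c2ccccc2CCC1C(=O)Nc1cc(C(F)(F)F)cc(C(F)(F)F)c1`: in a functional assay on PC-3 cells (Homo sapiens) for cytotoxicity, read by sulforhodamine B assay, with a stated time of 72 h (on this read-out higher numbers stand for weaker inhibition of growth and lower numbers for stronger inhibition of growth), compound 1 gives > 70000 nM, a limit of the assay rather than a number.
Compound 2, `O=C(Nc1cc(C(F)(F)F)cc(C(F)(F)F)c1)C1CCc2ccccc2N1C(=O)c1ccc(Cl)cc1`: in this assay compound 2 gives 4230 nM.

Compound 2 thus holds the only true number shown; the other entry sits at the limit of > 70000 nM in this assay, at which 1 of the 2 values shown sits. Compound 3, `CCC(=O)N1c2ccccc2CCC1C(=O)Nc1cc(C(F)(F)F)cc(C(F)(F)F)c1`, differs from compound 2 by ethyl in place of 4-chlorophenyl on a carbonyl carbon. Among the measured compounds shown here, the one measured step at this carbonyl, an at least 16-fold lower number from compound 1 to compound 2 (1.21 log units; beyond the scatter), went the other way, from methyl to 4-chlorophenyl. Ethyl stands nearer to methyl than to 4-chlorophenyl, so a large rise in the number is expected, a 14-fold higher number from compound 2 to compound 3 (1.15 log units; beyond the scatter). Compound 3 is estimated at 60000 nM, between 15000 nM and 200000 nM, with a fair chance that only a limit is reported.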

Compound 3, concentration for 50% growth inhibition: 8540 nM
Compound 3: the middle estimate sits 7.0-fold (0.85 log units) above what was measured; measured number outside the range, below it.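

At this carbonyl carbon, the ring of 4-chlorophenyl turns out not to be needed for growth inhibition in this assay, since replacing it with ethyl gives only a 2.0-fold higher number from compound 2 to compound 3 (0.31 log units; beyond the scatter). Methyl in place of hydrogen on the saturated chain carbon bound to this carbonyl carbon already gives an at least 8.1-fold lower number from compound 1 to compound 3 (0.91 log units; beyond the scatter). From the compounds shown here alone, compound 1 gives a limit, not a number, so the size of that step stays open: the limit of > 70000 nM in this assay, at which 1 of the 3 values shown sits.

Going by these compounds, whether a longer chain such as butyl, or an amine, would lower the number further remains open. So does what the chlorine itself contributes.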